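Swapping the Aminophenyl Ketone Arm for a Dichlorophenyl

The source may hold more compounds than are shown below. What is called first, only, known or untested is meant among the compounds shown, and "the series" means these compounds.

Compound 1 `COc1ccc(-c2cc(/C=C/C(=O)c3ccc(N)cc3)[nH]n2)cc1` and compound 2 `COc1cc(-c2cc(/C=C/C(=O)c3ccc(N)cc3)[nH]n2)cc(OC)c1OC` share a pyrazole-linked enone and differ only in the substitution of the aryl ring attached to the pyrazole. In a functional assay on NCI-H460 cells (Homo sapiens) for cytotoxicity, read by sulforhodamine B assay, with a stated time of 48 h, tested at 0.1 uM (a higher number here means a weaker effect of the compound at the concentration tested, a lower number a stronger effect), compound 1 gives 102%, and in this assay compound 2 gives 102%; the two stand level within the scatter, with both essentially inert at the concentration tested.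

Compound 3 `COc1cc(-c2cc(/C=C/C(=O)c3ccc(Cl)c(Cl)c3)[nH]n2)cc(OC)c1OC` has not yet been measured. It differs from compound 2 by 3,4-dichlorophenyl in place of 4-aminophenyl on a carbonyl carbon. For the measured compounds named here, no measured pair shows the effect of this change, so nothing in the data points to a gain or loss beyond the scatter. The step from compound 2 to compound 3 is therefore expected to be a number 4 percentage points lower from compound 2 to compound 3 (within the scatter), with neither direction favoured. Compound 3 is expected to give 98% in this assay, with a range from 85% to 108%.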

Compound 3, a percentage reported as activity, at one concentration (the size of the read-out at that concentration, not a potency): 105%
Compound 3: middle estimate off by 7 percentage points, on the low side; the measured number falls inside the stated range.
By their numbers in this assay, from the lowest: compounds 1, 2 and 3 (each within the scatter of the next).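

For the compounds shown here, this is the first view of the group on the carbonyl carbon. In this assay, putting 3,4-dichlorophenyl in place of 4-aminophenyl gives a number 3 percentage points higher from compound 2 to compound 3 (within the scatter), so at this concentration the read-out does not respond to the exchange, even though the hydrogen-bond donor and acceptor of 4-aminophenyl are absent from 3,4-dichlorophenyl. Nothing available bears on a reason for this result.

The compounds shown leave open whether a carboxylic acid or a morpholine on this phenyl ring, or a simple alkyl chain in place of the ring, would move the number. They also leave open whether any of these compounds has an effect at higher concentrations, and whether the same exchange would read alike on the core of compound 1.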